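Swapping chlorine for fluorine on the sulfonyl aryl

The compounds below may be only part of what the source reports. "The series", "measured", "known", "first", "only" and "open" are said of these compounds alone.

Measured compounds:
compound 1 `O=S(=O)(c1cc(F)cc(F)c1)c1cnc2c(F)cccc2c1-c1cccc(Cl)c1`: 0.64 mL/min
compound 2 `COc1ccc(S(=O)(=O)c2cnc3c(F)cccc3c2-c2cccc(F)c2)cc1`: 3.03 mL/min
compound 3 `O=S(=O)(c1cc(Cl)cc(Cl)c1)c1cnc2c(F)cccc2c1-c1cccc(F)c1`: 1.08 mL/min

In an ADME assay on microsomes from liver (Homo sapiens) for metabolic stability, tested at 2.5 uM (on this read-out higher numbers stand for fast clearance and lower numbers for slow clearance), compound 3 gives the second highest of the three numbers, with compound 1 nearest to it within the usual scatter and compound 2 furthest, beyond it. Going by the values given here, the one measured step that changes the ring on the sulfonyl sulfur, a 2.8-fold lower number from compound 2 to compound 3 (0.45 log units; beyond the scatter), shows that this position can shift the read-out modestly. Compound 4 `O=S(=O)(c1cc(F)cc(F)c1)c1cnc2c(F)cccc2c1-c1cccc(F)c1` carries 3,5-difluorophenyl in place of 3,5-dichlorophenyl on a sulfonyl sulfur. Among the compounds with values here, no measured step matches this exact change, but compound 1 also bears the 3,5-difluorophenyl group and its value sits close to that of compound 3. A small step downward, or none beyond the scatter, is therefore expected: a 1.4-fold lower number from compound 3 to compound 4 (0.16 log units; within the scatter). Compound 4 is estimated at 0.75 mL/min, with a range from 0.35 mL/min to 1.5 mL/min.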

Compound 4, intrinsic clearance in a liver preparation (reported as CLH), per the amount of preparation that the assay uses: 1.18 mL/min
Compound 4: the middle estimate sits 1.6-fold (0.20 log units) below what was measured, within the range that was stated.
By their numbers in this assay, from the lowest: compounds 1, 3 and 4 (each within the scatter of the next); then compound 2.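

In this assay, 3,5-difluorophenyl and 3,5-dichlorophenyl on the sulfonyl sulfur cannot be told apart (a 1.1-fold higher number from compound 3 to compound 4 (0.04 log units; within the scatter)). Like 3,5-dichlorophenyl, 3,5-difluorophenyl stands apart from 4-methoxyphenyl beyond the scatter (a 2.6-fold lower number from compound 2 to compound 4 (0.41 log units; beyond the scatter)). A second halogen exchange, fluoro in place of chloro on an aromatic carbon, also stays within the scatter (a 1.8-fold higher number from compound 1 to compound 4 (0.27 log units; within the scatter)).

No measured evidence bears on this result. On these data alone, whether a ring carrying an amine or a carboxylic acid on the sulfonyl sulfur would give a number outside this range remains open.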